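From 3-hydroxyphenyl to 4-methoxyphenyl

A few compounds are considered here, and "the series" means these few. Any claim that something is new, unique, unknown or untested is made for them only; others in the source may bear on it.

- Compound 1 `COc1ccc(Cn2nnc(O)c2C(=O)Nc2cccc(-c3ccccc3)c2)cc1`: 2.3
- Compound 2 `COc1ccc(Cn2nnc(O)c2C(=O)Nc2cccc(-c3cccc(O)c3)c2)cc1`: 2.25

In a physicochemical assay for lipophilicity, read by spectrophotometry, using the shake flask method, in phosphate buffer, measured as octanol-water partition, with a stated time of 4 h, at pH 7.4 (on this read-out lower numbers stand for lower lipophilicity and higher numbers for higher lipophilicity), compound 2 gives 2.25, level with compound 1 within the scatter. Compound 3 `COc1ccc(Cn2nnc(O)c2C(=O)Nc2cccc(-c3ccc(OC)cc3)c2)cc1` carries 4-methoxyphenyl in place of 3-hydroxyphenyl on an aromatic carbon. Within the data shown here, the one measured step that bears on this change, hydroxy in place of hydrogen on an aromatic carbon, is a number 0.05 log units lower from compound 1 to compound 2 (within the scatter). Among the measured compounds shown here, no measured compound carries 4-methoxyphenyl in this place, which leaves the expectation loose. The expected step in this assay is a number 0.15 log units higher from compound 2 to compound 3 (within the scatter), none beyond the scatter. For compound 3 the estimated value is 2.4, with an expected range from 2 to 2.8.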

Compound 3, distribution coefficient: 2.59
For compound 3 the middle estimate is 0.19 log units below the measured one; the range from low to high includes it.
By their numbers in this assay, from the lowest: compounds 2, 1 and 3 (each within the scatter of the next, the first and the last beyond it).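

In this assay, among these compounds, 4-methoxyphenyl in place of 3-hydroxyphenyl gives a number 0.34 log units higher from compound 2 to compound 3 (beyond the scatter), the first step at this position to pass the usual scatter, so the group here can move the number. Methoxy in place of hydrogen gives a number 0.29 log units higher from compound 1 to compound 3 (within the scatter), so the clear difference is from the hydroxy compound alone. Nothing available explains this step. From the compounds shown here alone, what an amine or a carboxylic acid in this place would do to the number stays open, as does a longer chain in place of methoxy.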